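The compounds below may be only part of what the source reports. "The series", "measured", "known", "first", "only" and "open" are said of these compounds alone.

Measured so far in a functional assay on L1210 cells (Mus musculus) for antiproliferative activity, read by cell counting, with a stated time of 2 days; a lower number here means a stronger inhibitor, a higher number a weaker inhibitor:
compound 1 (`COc1ccc(C(=O)c2sc(N3CCCC3)nc2N)cc1`): > 200000 nM as a limit
compound 2 (`Nc1nc(N2CCCC2)sc1C(=O)c1ccc(Br)cc1`): > 200000 nM as a limit

Among the measured compounds shown here, compound 2 thus stands only at a limit, as does the one other compound measured. Compound 3 (`Nc1nc(N2CCCC2)sc1C(=O)c1ccccc1`) differs from it by hydrogen in place of bromo on an aromatic carbon with hydrogen in place of bromo on an aromatic carbon. For the measured compounds named here, the one measured step at that place is a step that the two limits leave unreadable from compound 1 to compound 2 and it gives no readable size. Compound 1 and compound 2 both sit at the same limit (the limit of > 200000 nM in this assay, at which 2 of the 2 values shown sit) so in this assay no step beyond the scatter is expected, and another limit is likely. The estimate means an expected change of a number no higher from compound 2 to compound 3 (the limit leaves the size open) in either direction. For compound 3 the estimated value is 200000 nM (expected range 80000 nM to 400000 nM).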

Compound 3, half-maximal inhibitory concentration: > 200000 nM
Compound 3 gave a limit, no number; the forecaster's own chance of this, stated with the estimate: 85%; the middle value sits exactly at the limit.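

In this assay, among the compounds shown here, compound 3 gives > 200000 nM as a limit and not a number, so no step among compound 1, compound 2 and compound 3 can be read. From the compounds shown here alone, whether methoxy, bromo or hydrogen on the aromatic carbon makes any difference in this assay remains open.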